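The compounds below may be only part of what the source reports. "The series", "measured", "known", "first", "only" and "open" are said of these compounds alone.

Measured so far in a functional assay on Coronary artery (Bos taurus); on this read-out lower numbers stand for an effect already at smaller amounts and higher numbers for an effect only at larger amounts of compound:
- compound 1 `CCCCCNC(=O)NCCCC/C=C\CCCCCS(=O)(=O)c1ncn[nH]1`: 3100 nM
- compound 2 `CCCCCNC(=O)NCCCC/C=C\CCCCCCC1=NOS(=O)N1`: 340 nM
- compound 3 `CCCCCNC(=O)NCCCCCOc1cccc2sc(NC(C)=O)nc12`: 900 nM

Compound 3, at 900 nM, holds the middle place of the three. Compound 2 has a lower number at 340 nM, and compound 1 has a higher one at 3100 nM. Both gaps lie beyond the usual scatter.

The next compound is compound 4 `CCCCNC(=O)C(=O)NCCCCCOc1cccc2sc(NC(C)=O)nc12`, which keeps the core of compound 3 and changes the other end of the molecule: butylcarbamoyl in place of pentylamino on a carbonyl carbon. Read one bond further out, this is pentylcarbamoyl going to (butylcarbamoyl)carbonyl.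

For the measured compounds named here, only one step has been measured, a 9.1-fold lower number from compound 1 to compound 2 (0.96 log units; beyond the scatter). It bears on the new change only indirectly, since it exchanges a different group at a different place. It does show that a single replacement can move this assay by a modest amount, but it gives no direction for this change. Going by the values given here, no measured step touches the carbonyl region, so the expectation is weakly founded. A modest move towards a higher number is expected, with no move beyond the scatter still quite possible.

The expected step is a 1.7-fold higher number from compound 3 to compound 4 (0.22 log units; within the scatter).

The estimate for compound 4 is 1500 nM, with an expected range of 400 nM to 5500 nM.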

Compound 4, half-maximal effective concentration: 2400 nM
Compound 4: middle estimate off by 1.6-fold (0.20 log units), on the low side; low and high end bracket the measured number.
By their numbers in this assay, from the lowest: compound 2; then compound 3; then compounds 4 and 1 (each within the scatter of the next).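

In this assay, for the compounds shown here, the only measured change at this end of the molecule, on a carbonyl carbon whose other neighbour is an amide-type nitrogen, gives a 2.7-fold higher number from compound 3 to compound 4 (0.43 log units; beyond the scatter), so this end affects the read-out while the core of compound 3 stays fixed. Butylcarbamoyl carries a hydrogen-bond acceptor and a double bond that pentylamino lacks, with the same carbon and nitrogen counts and the same hydrogen-bond donor count, and here this exchange goes with an effect only at larger amounts of compound. No measured evidence on hand accounts for this step.

Going by these compounds alone, the single step combines the added carbonyl with the shift from a pentyl to a butyl end, so the two contributions stay unseparated; a (pentylcarbamoyl)carbonyl or (hexylcarbamoyl)carbonyl group would pull them apart. Also open, from the compounds shown here alone, is how a carboxylic acid or a cyclohexylamino group would read at this carbonyl carbon, and whether the same exchange would give a step of similar size on the chains of compound 1 and compound 2.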